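A furan-2-yl to pyridin-4-yl swap on the side chain

This account rests on a few compounds, and the source may have more. Where it says the series, first, only, none or still open, it means among the compounds named here.

In a functional assay on MCF7 cells (Homo sapiens) for inhibition, read by CCK-8 assay, with a stated time of 48 h (on this read-out lower numbers stand for stronger inhibition of growth and higher numbers for weaker inhibition of growth), compound 1 (`Cc1ccccc1Nc1nc(Nc2cccnc2)ncc1Cl`) gives 56500 nM. Compound 2 (`Cc1ccccc1Nc1nc(Nc2ccccc2)ncc1Cl`) reads > 100000 nM, which is a limit of the assay. Compound 3 (`Cc1ccccc1Nc1nc(NCc2ccco2)ncc1Cl`) reads > 100000 nM, also a limit, so it has no number of its own. Compound 4 (`Cc1ccccc1Nc1nc(NCc2ccncc2)ncc1Cl`) carries pyridin-4-yl in place of furan-2-yl on a saturated chain carbon bound to a nitrogen on an aromatic ring. The nearest guides are an at least 1.7-fold higher number from compound 1 to compound 2 (0.24 log units; that floor lies within the scatter) and an at least 1.7-fold higher number from compound 1 to compound 3 (0.24 log units; that floor lies within the scatter), where compound 1, with pyridin-3-yl, alone gives a number. Neither step is shown to exceed the scatter, so only a slight shift towards lower numbers is expected. The expected step is an at least 1.2-fold lower number from compound 3 to compound 4 (0.09 log units; that floor lies within the scatter). Compound 4 is estimated at 80000 nM, with an expected range from 35000 nM to 100000 nM.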

Compound 4, concentration for 50% growth inhibition: > 100000 nM
Compound 4 gave a limit, no number (the forecaster's own chance of this, stated with the estimate: 50%); middle value at least 1.2-fold (0.09 log units) away from the limit.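

Compound 4 reads > 100000 nM, a limit, so pyridin-4-yl on the saturated chain carbon gives no number of its own here. Set against the only measured number in the series, the change gives an at least 1.7-fold higher number from compound 1 to compound 4 (0.24 log units; that floor lies within the scatter), so no real difference is shown. The steps to compound 4 from compound 2 and compound 3 cannot be read because each joins two limits: the limit of > 100000 nM in this assay, at which 3 of the 4 values shown sit.

Still open, from the compounds shown here alone, is whether a longer chain carrying pyridin-4-yl, or an amine on the side chain, would give a measurable number.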